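The compounds below may be only part of what the source reports. "The series", "measured", "known", "first", "only" and "open" are said of these compounds alone.

Compound 1 `O=C(c1cccnc1)n1c(-c2ccccc2Cl)nc2ccccc21` carries a chloro group on its pendant ring and, in a physicochemical assay for lipophilicity, measured as octanol-water partition (on this read-out higher numbers stand for higher lipophilicity and lower numbers for lower lipophilicity), compound 1 gives 4.7. Compound 2 `O=C(c1cccnc1)n1c(-c2ccc(Cl)cc2)nc2ccccc21`, which carries a 4-chlorophenyl in place of the 2-chlorophenyl, gives 4.7 in this assay, so that no change at the digits printed from compound 1 to compound 2 (within the scatter). On the numbers shown, compound 1 stands level with compound 2 at the digits given.

Compound 3 `O=C(O)c1ccccc1-c1nc2ccccc2n1C(=O)c1cccnc1` is the subject of the next step. The change from compound 1 is carboxy in place of chloro on an aromatic carbon. Going by the values given here, no measured step here swaps one group for another group of a different kind; the only measured step, from compound 1 to compound 2, moves the same chloro group and is flat. It therefore offers no guide to the size of this step. Since a carboxy group replaces a chloro group, compound 3 is expected to come out lower in this assay, with an estimated a number 1.30 log units lower from compound 1 to compound 3 (beyond the scatter). The estimate for compound 3 is 3.4, within a range from 2.5 to 4.2.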

Compound 3, partition coefficient: 4.13
For compound 3 the middle estimate is 0.73 log units below the measured one, within the range that was stated.
By their numbers in this assay, from the lowest: compound 3; then compounds 1 and 2 (each within the scatter of the next).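

Replacing the chloro group with a carboxy group on this aromatic carbon, ortho to a large group, gives a number 0.57 log units lower from compound 1 to compound 3 (beyond the scatter) in this assay. Going by these compounds alone, the earlier step, which kept the chloro group and only moved it, gave no change at the digits printed from compound 1 to compound 2 (within the scatter), so this is the first sign that the kind of group at this position can shift the read-out, though only modestly. Nothing measured here accounts for the size of this step.

With a single swap at this position, the compounds shown do not tell whether an amine or a methyl ester would give a similar step. From the compounds shown here alone, it also remains open whether a carboxy group placed where compound 2 holds its chloro group would give the same number as compound 3.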